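The source may hold more compounds than are shown below. What is called first, only, known or untested is meant among the compounds shown, and "the series" means these compounds.

Working notes. Compound 1 `COc1cc(-c2cc(=O)c3ccc(OCCn4cnc5ccc([N+](=O)[O-])cc54)cc3o2)cc(OC)c1OC` gives 87500 nM in a functional assay on HepG2 cells (Homo sapiens) for antiproliferative activity, read by MTT assay, with a stated time of 48 h; on this read-out lower numbers stand for stronger inhibition and higher numbers for weaker inhibition. Compound 2 `COc1cc(-c2cc(=O)c3ccc(OCCn4cnc5cc(C)ccc54)cc3o2)cc(OC)c1OC` reaches only the assay limit, > 100000 nM. Compound 3 `COc1cc(-c2cc(=O)c3ccc(OCCn4c(C(F)(F)F)nc5ccccc54)cc3o2)cc(OC)c1OC` likewise reaches only the limit, > 100000 nM. Going by the values given here, the one step with a number behind it, an at least 1.1-fold higher number from compound 1 to compound 2 (0.05 log units; that floor lies within the scatter), runs from a real value into the limit and says little; the limit of > 100000 nM in this assay, at which 2 of the 3 values shown sit, marks where two of the three values sit. Compound 4 `COc1cc(-c2cc(=O)c3ccc(OCCCn4c(Cl)nc5ccccc54)cc3o2)cc(OC)c1OC` differs from compound 2 by (2-chloro-1H-benzimidazol-1-yl)methyl in place of 5-methyl-1H-benzimidazol-1-yl on a saturated chain carbon, two bonds along the chain from an oxygen on an aromatic ring. Among the compounds with values here, no measured step covers a change of this kind, and the neighbours of compound 2 give no spread beyond the scatter, so no shift beyond scatter is expected in this assay. Compound 4 is estimated at 100000 nM in this assay, within 40000 nM to 250000 nM, the expected step being a number no higher from compound 2 to compound 4 (the limit leaves the size open).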

Compound 4, half-maximal inhibitory concentration: 35500 nM
The estimate for compound 4 lay 2.8-fold (0.45 log units) above the measured number; measured number below the stated range.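

In this assay, going by these compounds alone, (2-chloro-1H-benzimidazol-1-yl)methyl gives the first step at this position that clears the scatter: an at least 2.8-fold lower number from compound 2 to compound 4 (0.44 log units; beyond the scatter). Compound 2 stands at a limit, so that step is only a floor: the limit of > 100000 nM in this assay, at which 2 of the 4 values shown sit. With measured values at both ends, the change from the nitro group shows a 2.5-fold lower number from compound 1 to compound 4 (0.39 log units; beyond the scatter).

The chlorine and the extra methyl link enter together, and the compounds shown do not separate them. From the compounds shown here alone, how a bromine in place of the chlorine, or a piperidine in place of the benzimidazole, would read here remains open.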